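Swapping an Isopropyl for a Cyclopropyl on the Ester

This account rests on a few compounds, and the source may have more. Where it says the series, first, only, none or still open, it means among the compounds named here.

Of the compounds shown here, three sharing one core have been measured in an assay on membranes from HEK293 cells for displacement of a labelled ligand from adenosine receptor A2b (Homo sapiens), read by scintillation counting, with a stated time of 30 min; on this read-out higher numbers stand for weaker inhibition and lower numbers for stronger inhibition. Compound 1 `CC1=C(C(=O)OCC(C)C)C(c2ccoc2)NC(=O)N1` gives 326 nM; compound 2 `CC1=C(C(=O)OCC(C)C)C(c2cccs2)NC(=O)N1` gives 2130 nM; compound 3 `CC1=C(c2ncc(C)o2)C(c2ccsc2)NC(=O)N1` gives 1130 nM. Compound 2 carries the highest of the three numbers, yet its gap to compound 3 is within the scatter, so the two cannot be ranked against each other. Within the data shown here, the one single-change step available, a 6.5-fold higher number from compound 1 to compound 2 (0.82 log units; beyond the scatter), concerns the aromatic ring on the saturated ring carbon and says nothing about the ester side chain.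

Compound 4 `CC1=C(C(=O)OCC2CC2)C(c2cccs2)NC(=O)N1` differs from compound 2 by cyclopropyl in place of isopropyl on a saturated chain carbon bound to an oxygen next to a carbonyl group. Among the measured compounds shown here, no measured step touches this part of the molecule, and the change keeps the number of heavy atoms, donors and acceptors the same. The expectation is therefore a step of a 1.1-fold lower number from compound 2 to compound 4 (0.03 log units; within the scatter), that is, none beyond the scatter. Compound 4 is thus estimated at 2000 nM in this assay, with a range from 700 nM to 6000 nM.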

Compound 4, inhibition constant: 1570 nM
Beside the measured number, compound 4's estimate is 1.3-fold (0.11 log units) above it, within the range that was stated.
By their numbers in this assay, from the lowest: compound 1; then compounds 3, 4 and 2 (each within the scatter of the next).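

Among these compounds, this is the first measured change at this place, a saturated chain carbon bound to an oxygen next to a carbonyl group. In this assay, closing isopropyl into cyclopropyl gives a 1.4-fold lower number from compound 2 to compound 4 (0.13 log units; within the scatter), so the two groups cannot be told apart in this setting, where the aromatic ring on the saturated ring carbon is thiophen-2-yl. The step between the aromatic rings, a 6.5-fold higher number from compound 1 to compound 2 (0.82 log units; beyond the scatter), remains the only one here beyond the scatter, and no available evidence bears on this result.

Going by these compounds, whether the same swap would also make no clear difference with the furan-3-yl ring of compound 1 remains open. Also open, on these data alone, is how a longer chain such as hexyl, or a chain ending in an amine or a carboxylic acid, would read at this place.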